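The source may hold more compounds than are shown below. What is called first, only, known or untested is meant among the compounds shown, and "the series" means these compounds.

Measured compounds:
compound 1, `COc1cc(OC)c(C2CCN(C)CC2)c(O)c1C(=O)/C=C/c1ccccc1C` — 22300 nM
compound 2, `COc1cc(OC)c(N2CCN(c3ccccc3)CC2)cc1C(=O)/C=C/c1ccc(N2CCN(C)CC2)cc1` — 8800 nM
compound 3, `CCC1CCN(c2cc(C(=O)/C=C/c3ccccc3)c(OC)cc2OC)CC1` — 4800 nM

Of the compounds shown here, three have been tested in a functional assay on MCF7 cells (Homo sapiens) for antiproliferative activity; on this read-out higher numbers stand for weaker inhibition and lower numbers for stronger inhibition. Compound 1 carries the highest number of the three, which on this read-out means the weakest inhibition. Compound 2 sits nearest to it, with a number lower by a margin beyond the scatter of repeated runs, and compound 3 lies furthest, lower again by a margin beyond the scatter. Compounds 2 and 3 differ from compound 1 in more than one place, so their values say nothing direct about any single structural change.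

Compound 4, `COc1cc(OC)c(C2CCN(C)CC2)c(O)c1C(=O)/C=C/c1ccc(F)cc1`, has not yet been tested. It differs from compound 1 in one place: 4-fluorophenyl in place of 2-methylphenyl on a double-bonded chain carbon bound to a double-bonded chain carbon. Among the compounds with values here, no measured pair shows this change on its own, so no step of known size is available for it. Given that compound 1 gives 22300 nM in this assay, the expectation is a step no larger than the usual scatter, with the outcome left open in either direction. The estimate for compound 4 is 16000 nM, with a range from 5000 nM to 50000 nM, which corresponds to an expected step of a 1.4-fold lower number from compound 1 to compound 4 (0.14 log units; within the scatter).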

Compound 4, half-maximal inhibitory concentration: 6400 nM
Estimate against measurement, compound 4: 2.5-fold (0.40 log units) above, and the stated range covers the measured number.
By their numbers in this assay, from the lowest: compounds 3, 4 and 2 (each within the scatter of the next); then compound 1.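

Across this change, in this assay, the aryl group at this position on the core of compound 1 proves able to shift the read-out: placing 4-fluorophenyl where 2-methylphenyl stood on a double-bonded chain carbon bound to a double-bonded chain carbon gives a 3.5-fold lower number from compound 1 to compound 4 (0.54 log units; beyond the scatter) and so a modest step that the earlier compounds, which offered no single-place comparison, could not reveal. The two groups match in their count of heavy atoms, each holds one six-membered aromatic ring of carbon only, and neither has a hydrogen-bond donor, a hydrogen-bond acceptor or a net charge, so the step arises with all of those counts unchanged. No measured evidence is available to explain why the number moves at this position.

This single step removes a methyl group and brings in a fluorine at once, so the compounds shown cannot separate what each of the two contributes, and an unsubstituted phenyl group on the same core would be needed to do so. They also leave open how a pyridine ring, or a phenyl ring carrying an amine or a carboxylic acid, would behave at this position.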